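A few compounds are considered here, and "the series" means these few. Any claim that something is new, unique, unknown or untested is made for them only; others in the source may bear on it.

Compound 1, `COc1ccc(S(=O)(=O)N(CC(N)=O)c2ccc(N(CC(N)=O)S(=O)(=O)c3ccc(SCCCCN=C=S)cc3)c3ccccc23)cc1`, gives in an ADME assay on cells (Peritoneal macrophage, Mus musculus) for cytotoxicity, read by CCK-8 assay, with a stated time of 24 h (a lower number here means that less compound is tolerated, a higher number that more compound is tolerated), the limit > 10000 nM.
Compound 2, `COc1ccc(S(=O)(=O)N(CC(N)=O)c2ccc(N(CC(N)=O)S(=O)(=O)c3ccc([S+]([O-])CCOCCN=C=S)cc3)c3ccccc23)cc1`, gives in this assay the limit > 10000 nM.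
Compound 3, `COc1ccc(S(=O)(=O)N(CC(N)=O)c2ccc(N(CC(N)=O)S(=O)(=O)c3ccc(S(=O)(=O)CCCCCN=C=S)cc3)c3ccccc23)cc1`, gives in this assay the limit > 10000 nM.

Compound 1 thus stands only at a limit, and the two further values shown are limits as well: all three sit at the limit of > 10000 nM in this assay, at which 3 of the 3 values shown sit. Compound 4, `COc1ccc(S(=O)(=O)N(CC(N)=O)c2ccc(N(CC(N)=O)S(=O)(=O)c3ccc(N=C=S)cc3)c3ccccc23)cc1`, differs from compound 1 by a group of 3 heavy atoms (1 carbon, 1 nitrogen, 1 sulfur; no ring) in place of a group of 8 heavy atoms (5 carbon, 1 nitrogen, 2 sulfur; no ring), on an aromatic carbon. The steps that start from compound 1, a step that the two limits leave unreadable from compound 1 to compound 2 and a step that the two limits leave unreadable from compound 1 to compound 3, bear on this change, yet neither can be read because every value involved sits at the limit of > 10000 nM in this assay, at which 3 of the 3 values shown sit. For the measured compounds named here, no size of step in this assay can be drawn from them, in either direction. For compound 4 a value at the same limit is expected, estimated as 20000 nM with a range from 10000 nM to 40000 nM. The step this estimate means, a step that the limit leaves unreadable from compound 1 to compound 4, is expected to stay within the scatter.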

Compound 4, half-maximal cytotoxic concentration: > 10000 nM
Compound 4: only a limit was reported; the forecaster's own chance of this, stated with the estimate: 85%; the middle value is on the limit's open side.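

Compound 4 joins compounds 1, 2 and 3 at a limit, so no step among them can be read: the limit of > 10000 nM in this assay, at which 4 of the 4 values shown sit.

The compounds shown leave open how far any of these chains changes what the cells tolerate in this assay.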